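Replacing the methylpyridyl arm of compound 3 with bromophenyl

A few compounds are considered here, and "the series" means these few. Any claim that something is new, unique, unknown or untested is made for them only; others in the source may bear on it.

Measured in a functional assay on A549 cells (Homo sapiens) for antiproliferative activity, read by MTT assay; on this read-out lower numbers stand for stronger inhibition and higher numbers for weaker inhibition: compound 1 `COc1ccc(/C=C2/SC(N3CCC[C@H]3C(=O)Nc3ccc4ncnc(Nc5cccc(Cl)c5)c4c3)=NC2=O)cc1` gives 31700 nM. Compound 2 `O=C1N=C(N2CCC[C@H]2C(=O)Nc2ccc3ncnc(Nc4cccc(Cl)c4)c3c2)S/C1=C/c1ccccc1Cl` gives only a limit of the assay, > 50000 nM. Compound 3 `Cc1cccc(/C=C2/SC(N3CCC[C@H]3C(=O)Nc3ccc4ncnc(Nc5cccc(Cl)c5)c4c3)=NC2=O)n1` gives 8500 nM.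

Compound 3 holds the lowest of the two numbers; its nearest neighbour is compound 1, and the gap a 3.7-fold lower number from compound 1 to compound 3 (0.57 log units; beyond the scatter) is beyond the scatter. Compound 4 `O=C1N=C(N2CCC[C@H]2C(=O)Nc2ccc3ncnc(Nc4cccc(Cl)c4)c3c2)S/C1=C/c1ccccc1Br` differs from it by 2-bromophenyl in place of 6-methylpyridin-2-yl on a double-bonded chain carbon bound to a double-bonded ring carbon. The step that bears on this is an at least 5.8-fold lower number from compound 2 to compound 3 (0.76 log units; beyond the scatter), which runs the same way in reverse, since 2-bromophenyl sits close to 2-chlorophenyl; the step of an at least 1.5-fold higher number from compound 1 to compound 2 (0.19 log units; that floor lies within the scatter) also points upward. Compound 4 is therefore expected to show a 5.3-fold higher number from compound 3 to compound 4 (0.72 log units; beyond the scatter). Compound 4 is estimated at 45000 nM, within 15000 nM to 150000 nM, with a fair chance that only a limit is reported.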

Compound 4, half-maximal inhibitory concentration: > 50000 nM
Compound 4 gave a limit, no number (the forecaster's own chance of this, stated with the estimate: 50%); middle value at least 1.1-fold (0.04 log units) away from the limit.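

Compound 4 gives only a limit, not a number, yet it shows that a second halogen-bearing phenyl arm also fails to keep the lower number of compound 3 (an at least 5.8-fold higher number from compound 3 to compound 4 (0.76 log units; beyond the scatter)). The comparison with the methoxyphenyl arm stays undecided, since its floor lies within the scatter (an at least 1.5-fold higher number from compound 1 to compound 4 (0.19 log units; that floor lies within the scatter)). Bromo in place of chloro cannot be read, because both compounds stop at the same ceiling: the limit of > 50000 nM in this assay, at which 2 of the 4 values shown sit.

Open, on these data alone, is whether the nitrogen or the methyl of 6-methylpyridin-2-yl accounts for its lower number. Also open, as far as these compounds go, is how an arm carrying an amine or a carboxylic acid would compare.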